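Replacing Fluoro with Phenoxy on Compound 2

This account rests on a few compounds, and the source may have more. Where it says the series, first, only, none or still open, it means among the compounds named here.

Measured compounds:
- compound 1 `CN[C@@H]1CC[C@@H](c2ccc(F)cc2)c2ccccc21`: 30 nM
- compound 2 `CN[C@H]1CC[C@@H](c2ccc(F)cc2)c2ccccc21`: 2300 nM

In a functional assay on Hypothalamus for inhibition of Norepinephrine transporter (Rattus norvegicus) (on this read-out lower numbers stand for stronger inhibition and higher numbers for weaker inhibition), compound 1 gives 30 nM, while compound 2 gives 2300 nM. Compound 2 thus has the higher of the two numbers, meaning the weaker inhibition. The two compounds share all atoms and bonds and differ only in the configuration at one saturated ring carbon, and that one change amounts to a 77-fold higher number from compound 1 to compound 2 (1.88 log units; beyond the scatter).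

Compound 3 `CN[C@H]1CC[C@@H](c2ccc(Oc3ccccc3)cc2)c2ccccc21` keeps the configuration of compound 2 and alters the substituent on the outer aromatic ring: phenoxy in place of fluoro on an aromatic carbon. Going by the values given here, no measured step involves such an exchange; the only measured step concerns configuration alone, so it offers no guide to the size or direction of the change in this assay. The expectation for compound 3 is therefore wide and centred near the number for compound 2. Compound 3 is estimated at 2000 nM, within a range from 400 nM to 10000 nM. This estimate corresponds to an expected step of a 1.2-fold lower number from compound 2 to compound 3 (0.06 log units; within the scatter).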

Compound 3, half-maximal inhibitory concentration: 3900 nM
Compound 3: middle estimate off by 2.0-fold (0.29 log units), on the low side; the range from low to high includes it.
By their numbers in this assay, from the lowest: compound 1; then compounds 2 and 3 (each within the scatter of the next).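

In this assay, putting phenoxy in place of fluoro on this aromatic carbon gives a 1.7-fold higher number from compound 2 to compound 3 (0.23 log units; within the scatter). That step lies within the scatter, so compound 2 and compound 3 cannot be told apart here, even though phenoxy brings its own six-membered aromatic ring of carbon only. What is known about these compounds offers no explanation for this result.

Going by these compounds alone, the exchange was read only with the configuration of compound 2, so it remains open whether phenoxy would leave the number just as unmoved with the configuration of compound 1, the one compound here with a clearly lower number. Going by these compounds, it is also open whether an amine or a carboxylic acid at this same position would leave the number within the scatter of compound 2.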